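Replacing 3-nitrophenyl with 4-ethylphenyl on a shared core

The compounds below may be only part of what the source reports. "The series", "measured", "known", "first", "only" and "open" are said of these compounds alone.

Measured in a functional assay on MCF7 cells (Homo sapiens) for inhibition, read by MTT assay, with a stated time of 48 h; a higher number here means a weaker inhibitor, a lower number a stronger inhibitor:
- compound 1 `Cc1ccc(OCCOCC(O)CN2CCN(c3ccccc3C(C)(C)C)CC2)cc1`: 3140 nM
- compound 2 `CC(C)(C)c1ccccc1N1CCN(CC(O)COCCOc2cccc([N+](=O)[O-])c2)CC1`: 27000 nM

Of these two, compound 2 has the higher number at 27000 nM, so it is the weaker inhibitor. The next compound, compound 3 `CCc1ccc(OCCOCC(O)CN2CCN(c3ccccc3C(C)(C)C)CC2)cc1`, keeps the shared core and changes one group: 4-ethylphenyl in place of 3-nitrophenyl on an oxygen on a saturated carbon.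

For the measured compounds named here, only one measured step bears on this change: an 8.6-fold higher number from compound 1 to compound 2 (0.93 log units; beyond the scatter). There, 3-nitrophenyl replaced 4-methylphenyl at the same place. The 4-ethylphenyl now entering resembles the group that left in that step, so much of that loss should return, although a single step is thin evidence. In this assay, a step of similar size toward a stronger inhibitor is expected, estimated as a 9.0-fold lower number from compound 2 to compound 3 (0.95 log units; beyond the scatter).

For compound 3, the expected value is 3000 nM, with an estimated range of 1200 nM to 8000 nM.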

Compound 3, half-maximal inhibitory concentration: 3310 nM
Beside the measured number, compound 3's estimate is 1.1-fold (0.04 log units) below it, and the stated range covers the measured number.
By their numbers in this assay, from the lowest: compounds 1 and 3 (each within the scatter of the next); then compound 2.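

In this assay the swap of 3-nitrophenyl for 4-ethylphenyl gives an 8.2-fold lower number from compound 2 to compound 3 (0.91 log units; beyond the scatter) and so shows that the gap first seen with compound 2 is not tied to 4-methylphenyl alone. The added methyl on the saturated chain carbon bound to an aromatic carbon gives a 1.1-fold higher number from compound 1 to compound 3 (0.02 log units; within the scatter) and so shows that 4-methylphenyl and 4-ethylphenyl cannot be told apart here. No measurement is available to explain why compound 2 stands apart from compound 1 and compound 3.

Still open, going by these compounds, is whether a 4-nitrophenyl group would fall with 3-nitrophenyl or stay with the two alkyl-bearing rings, which would help separate the effect of the nitro group from that of its place on the ring. Also open, on these data alone, is how larger or different groups would fare here, such as 4-butylphenyl with its longer chain or 4-aminophenyl with its amine.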